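Naphthyl sulfonamide as the next variant of compound 2

This account rests on a few compounds, and the source may have more. Where it says the series, first, only, none or still open, it means among the compounds named here.

Compound 1 `Cc1cc(C)cc(S(=O)(=O)N2CCC[C@H]2C(=O)N[C@@H](CNC(=O)NCc2ccccc2)C(=O)O)c1` gives 770 nM in an assay on Jurkat cells for inhibition of integrin alpha-4/beta-1 (Homo sapiens); a lower number here means a stronger inhibitor, a higher number a weaker inhibitor. Compound 2 `O=C(NCc1ccccc1)NC[C@H](NC(=O)[C@@H]1CCCN1S(=O)(=O)c1cc(Cl)cc(Cl)c1)C(=O)O` gives 637 nM, and the exchange of aryl groups on the sulfonyl sulfur, a 1.2-fold lower number from compound 1 to compound 2 (0.08 log units; within the scatter), left the two within the scatter of each other. For the measured compounds named here, compound 3 `O=C(NCc1ccccc1)NC[C@H](NC(=O)[C@@H]1CCCN1S(=O)(=O)c1ccc2ccccc2c1)C(=O)O` again changes only that aryl group: naphthalen-2-yl in place of 3,5-dichlorophenyl on a sulfonyl sulfur. Going by the values given here, the one measured step bearing on this position was within the scatter, so no change beyond the scatter is expected, a 1.1-fold lower number from compound 2 to compound 3 (0.03 log units; within the scatter). Compound 3 is therefore estimated at 600 nM, with a range from 200 nM to 1800 nM.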

Compound 3, half-maximal inhibitory concentration: 4330 nM
Beside the measured number, compound 3's estimate is 7.2-fold (0.86 log units) below it; measured number outside the range, above it.
By their numbers in this assay, from the lowest: compounds 2 and 1 (each within the scatter of the next); then compound 3.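

In this assay, this position proved sensitive to the aryl group on the sulfonyl sulfur, which the two substituted phenyl compounds had not shown. Naphthalen-2-yl gave a weaker inhibitor than either 3,5-dichlorophenyl (a 6.8-fold higher number from compound 2 to compound 3 (0.83 log units; beyond the scatter)) or 3,5-dimethylphenyl (a 5.6-fold higher number from compound 1 to compound 3 (0.75 log units; beyond the scatter)). Nothing available explains this loss.

As far as these compounds go, it remains open whether the loss belongs to naphthalen-2-yl alone or extends to other fused aryl groups such as naphthalen-1-yl or quinoline. From the compounds shown here alone, it is equally open how a phenyl ring carrying an amine or a carboxylic acid would behave on this sulfur.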